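The source may report more compounds than this note shows. Statements on the series, on what has been measured and on what is new or still open speak of the compounds shown alone.

Series notes. Compound 1 is `CCCCCC(CCO)n1cnc2c(N)ncnc21`. In a functional assay on SW480 cells (Homo sapiens) for antiproliferative activity, read by MTT assay, with a stated time of 48 h (on this read-out higher numbers stand for weaker inhibition and lower numbers for stronger inhibition), compound 1 gives > 50000 nM, which is a limit of the assay rather than a number. Compound 2 is `CCCCCC(CCO)n1cnc2cncnc21`, reached from compound 1 by hydrogen in place of amino on an aromatic carbon. In this assay compound 2 gives > 50000 nM, again a limit of the assay. The step that the two limits leave unreadable from compound 1 to compound 2 therefore cannot be read, since both values sit at the limit of > 50000 nM in this assay, at which 2 of the 2 values shown sit. Among the compounds with values here, compound 1 thus stands only at a limit, and the one further value shown is a limit as well.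

Compound 3 is `CCCCCCCCCCC(CCO)n1cnc2c(N)ncnc21`. It differs from compound 1 as follows: pentyl in place of hydrogen on a saturated chain carbon, six bonds along the chain from an aromatic nitrogen. Within the data shown here, no measured step concerns this change; the single measured step, a step that the two limits leave unreadable from compound 1 to compound 2, touches the aromatic carbon and not the saturated chain carbon, and its size is not readable. No direction can be expected beyond the scatter in this assay. Compound 3 is expected to give 60000 nM, with a range of 20000 nM to 200000 nM. The step that the limit leaves unreadable from compound 1 to compound 3 is thus estimated to leave compound 3 near the same limit, most probably reported as a limit once more.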

Compound 3, half-maximal inhibitory concentration: 1200 nM
Compound 3: the middle estimate sits 50-fold (1.70 log units) above what was measured; the measured number lies below the stated range.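

In this assay, within the data shown here, the saturated chain carbon six bonds along the chain from an aromatic nitrogen is the first place where a change gives a readable effect: pentyl in place of hydrogen there gives an at least 41-fold lower number from compound 1 to compound 3 (1.61 log units; beyond the scatter). Compound 1 gives > 50000 nM, which is a limit of the assay. Compound 3 is therefore the only compound shown with a value that reads as a number, while the step for hydrogen in place of amino on an aromatic carbon cannot be read: the limit of > 50000 nM in this assay, at which 2 of the 3 values shown sit.

From the compounds shown here alone, with one chain change on record, it stays open how the value moves if the pentyl is replaced by a shorter group such as methyl, by a longer chain, or by a chain carrying an amine or a carboxylic acid. Among these compounds, the contribution of the amino group also stays open, as hydrogen in place of amino on an aromatic carbon is seen only on the shorter chain of compound 1 and not on the chain of compound 3, where a value off the limit would give a step that can be read.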